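The source may report more compounds than this note shows. Statements on the series, on what has been measured and on what is new or still open speak of the compounds shown alone.

Compound 1 `Nc1cc(-c2ccccc2)ccc1Cn1cncc1CNc1ccc(-c2cncs2)c(-c2ccccc2)c1` in a toxicity assay on NIH3T3 cells (Mus musculus) for cytotoxicity, read by resazurin assay (on this read-out lower numbers stand for an effect already at smaller amounts and higher numbers for an effect only at larger amounts of compound), gives > 1000 nM, a limit of the assay rather than a number. Compound 2 `O=C(c1ccc(NCc2cncn2Cc2ccc(-c3ccccc3)cc2)cc1-c1ccccc1)N1CCCCC1` in this assay gives > 1000 nM, also a limit. Compound 3 `Clc1ccc(Cn2cncc2CNc2cccc(-c3ccccc3)c2)cc1` in this assay gives 10000 nM.

Compound 2 thus sits at the limit of > 1000 nM in this assay, at which 2 of the 3 values shown sit, so its reading is a bound and not a measured number. Compound 4 `COC(=O)c1ccc(NCc2cncn2Cc2ccc(-c3ccccc3)cc2)cc1-c1ccccc1` has not yet been measured; it differs from compound 2 by methoxy in place of piperidin-1-yl on a carbonyl carbon. For the measured compounds named here, no measured pair isolates this change. Going by the values given here, because compound 3 gives 10000 nM, weak cytotoxicity is the only number in hand, and the step is expected to be small, with no clear direction beyond the scatter. Compound 4 is therefore expected to give about 3000 nM, in the range 1000 nM to 10000 nM. This is expected to amount to a step that the limit leaves unreadable from compound 2 to compound 4.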

Compound 4, half-maximal effective concentration: > 1000 nM
Compound 4 was reported as a limit (the forecaster's own chance of this, stated with the estimate: 60%); the middle value does not contradict the limit.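

Compound 2 and compound 4 both stand at a limit of the assay, and no step can be read between them. Left open is how far methoxy in place of piperidin-1-yl on a carbonyl carbon shifts the reading in this assay.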